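The source may hold more compounds than are shown below. What is called first, only, known or untested is meant among the compounds shown, and "the series" means these compounds.

Working notes on the series. In an ADME assay on Vero cells (Chlorocebus sabaeus) for cytotoxicity, read by resazurin assay, with a stated time of 2 days (on this read-out higher numbers stand for lower toxicity in this test and lower numbers for higher toxicity in this test), compound 1 `CC(=O)O[C@@H]1[C@@H](OC(C)=O)[C@H](OC(C)=O)CO[C@H]1CC(=O)/C=C/c1cccc(NC(=S)Nc2ccccc2)c1` gives 58700 nM. Compound 2 `CCOC(=O)/C=C/c1cccc(NS(=O)(=O)c2ccc(C)cc2)c1` gives 77100 nM in this assay, and the two values lie within the scatter of each other, so no order between them can be read. For the measured compounds named here, compound 3 `CC(=O)OC[C@H]1O[C@@H](CC(=O)/C=C/c2cccc(NC(=S)Nc3ccccc3)c2)[C@H](OC(C)=O)[C@@H](OC(C)=O)[C@@H]1OC(C)=O` gives 337000 nM in this assay; the step of a 5.7-fold higher number from compound 1 to compound 3 (0.76 log units; beyond the scatter) is the only measured step in the set and it concerns an acetoxymethyl on a saturated ring carbon, not the part of the molecule changed here.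

Compound 4 `CC(=O)O[C@@H]1[C@@H](OC(C)=O)[C@H](OC(C)=O)CO[C@H]1CC(=O)/C=C/c1cccc(NC(=O)Nc2ccccc2)c1` differs from compound 1 as follows: a group of 9 heavy atoms (7 carbon, 1 nitrogen, 1 oxygen; one six-membered aromatic ring of carbon only) in place of a group of 9 heavy atoms (7 carbon, 1 nitrogen, 1 sulfur; one six-membered aromatic ring of carbon only), on a nitrogen on an aromatic ring. Going by the values given here, no measured pair in the set varies this position, so there is no step that bears directly on the change, and the expectation can rest only on the value of compound 1 in this assay, 58700 nM, together with the unchanged remainder of the structure. The step of a 1.2-fold higher number from compound 1 to compound 4 (0.08 log units; within the scatter) is therefore expected to stay within the scatter, in no firm direction. For compound 4 in this assay the estimate is 70000 nM, with a range from 25000 nM to 190000 nM.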

Compound 4, half-maximal cytotoxic concentration: 102000 nM
Compound 4: middle estimate off by 1.5-fold (0.16 log units), on the low side; the range from low to high includes it.
By their numbers in this assay, from the lowest: compounds 1, 2 and 4 (each within the scatter of the next); then compound 3.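

In this assay, the exchange at this nitrogen on an aromatic ring gives a 1.7-fold higher number from compound 1 to compound 4 (0.24 log units; within the scatter) and thus stays within the scatter. For the compounds shown here, with the shared core unchanged, phenylcarbamoyl in place of its sulfur-bearing counterpart of equal heavy-atom count gives no readable difference in this test, and this pair is the first measured information on the position. No supporting measurement bears on this result.

Still open, on these data alone, is whether a more different group on this nitrogen, such as acetyl, methanesulfonyl or benzyl, or a free amine in place of the substituted nitrogen, would give a step beyond the scatter. Also open, as far as these compounds go, is whether the same oxygen-for-sulfur exchange gives a similar result on the core of compound 3, which carries the acetoxymethyl.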